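The source may hold more compounds than are shown below. What is called first, only, known or untested is meant among the compounds shown, and "the series" means these compounds.

Compound 1 `CCOC(=O)c1cc(-c2cccc(OCc3cccc(Cl)c3)c2)on1` has in an ADME assay on Vero cells (Chlorocebus sabaeus) for cytotoxicity, with a stated time of 72 h (a lower number here means a stronger inhibitor, a higher number a weaker inhibitor), a result of > 128000 nM, which is a limit of the assay and not a number. Compound 2 `CCOC(=O)c1cc(-c2cccc(OCc3cccc(F)c3F)c2)on1` returns in this assay > 128000 nM, again a limit rather than a number. The step that the two limits leave unreadable from compound 1 to compound 2 therefore cannot be read, because the limit of > 128000 nM in this assay, at which 2 of the 2 values shown sit: both results sit at the same limit, so compound 2 stands only at that limit, with no measured number of its own in this assay. Compound 3 `CCOC(=O)c1cc(-c2cccc(OCc3c(F)cccc3F)c2)on1` is the next member; it carries 2,6-difluorophenyl in place of 2,3-difluorophenyl on a saturated chain carbon bound to an oxygen on an aromatic ring. Going by the values given here, the sole measured step is the unreadable one from compound 1 to compound 2, so there is no readable step to bear on this change, and no size or direction beyond the scatter can be expected for a step that the limit leaves unreadable from compound 2 to compound 3. For compound 3 the expected result in this assay is 200000 nM, with a range from 100000 nM to 500000 nM.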

Compound 3, half-maximal inhibitory concentration: > 128000 nM
Compound 3: a limit, no number (the forecaster's own chance of this, stated with the estimate: 85%); the middle value does not contradict the limit.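

No new step can be read in this assay between compound 1, compound 2 and compound 3, since each result is a limit and not a number: the limit of > 128000 nM in this assay, at which 3 of the 3 values shown sit. The compounds shown leave open whether the 3-chlorophenyl, 2,3-difluorophenyl and 2,6-difluorophenyl compounds differ at all in this assay.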